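The compounds below may be only part of what the source reports. "The series", "measured", "known", "first", "only" and "open" are said of these compounds alone.

Measured so far in a functional assay on MDA-MB-231 cells (Homo sapiens) for antiproliferative activity, read by MTT assay, with a stated time of 24 h; on this read-out lower numbers stand for stronger inhibition and higher numbers for weaker inhibition:
compound 1 `CCCSc1nnc(COc2cc(C)c3c(C)cc(=O)oc3c2)o1`, a limit only: > 100000 nM
compound 2 `CCCCCCSc1nnc(COc2cc(C)c3c(C)cc(=O)oc3c2)o1`, a limit only: > 100000 nM
compound 3 `Cc1cc(OCc2nnc(SCc3cccc(F)c3)o2)cc2oc(=O)cc(C)c12`, a limit only: > 100000 nM

Compound 3 therefore stands nowhere on a scale of numbers: its value in this assay is a limit, and the same holds for the two other compounds of the series, all of which sit at the limit of > 100000 nM in this assay, at which 3 of the 3 values shown sit. The steps between them, a step that the two limits leave unreadable from compound 1 to compound 2, a step that the two limits leave unreadable from compound 1 to compound 3 and a step that the two limits leave unreadable from compound 2 to compound 3, are for that reason unreadable in size and direction; they say only that neither lengthening the chain on the sulfur nor exchanging it for the 3-fluorobenzyl group brought any compound to a measurable number.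

The next compound, compound 4 `CCCS(=O)(=O)c1nnc(COc2cc(C)c3c(C)cc(=O)oc3c2)o1`, differs from compound 3 by propylsulfonyl in place of (3-fluorobenzyl)sulfanyl on an aromatic carbon. Among the compounds with values here, no measured step alters the sulfur itself or its oxidation state, so none of them bears directly on this change; what the series shows is three compounds at the limit and no readable step at all. On that basis compound 4 is expected to remain at or near the limit, with an estimate of 150000 nM and a range from 40000 nM to 600000 nM. The step that the limit leaves unreadable from compound 3 to compound 4 is accordingly expected to be none beyond the scatter, and most likely the assay will again report only a limit.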

Compound 4, half-maximal inhibitory concentration: 7070 nM
Compound 4: the middle estimate sits 21-fold (1.33 log units) above what was measured; measured number below the stated range.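

Within the data shown here, the exchange of propylsulfanyl for propylsulfonyl on this aromatic carbon keeps the propyl chain and alters only the sulfur, and in this assay it gives the first readable number of the series (an at least 14-fold lower number from compound 1 to compound 4 (1.15 log units; beyond the scatter)). The two comparisons that also change the chain point the same way, with propylsulfonyl in place of hexylsulfanyl (an at least 14-fold lower number from compound 2 to compound 4 (1.15 log units; beyond the scatter)) and in place of (3-fluorobenzyl)sulfanyl (an at least 14-fold lower number from compound 3 to compound 4 (1.15 log units; beyond the scatter)), but these alter the chain and the sulfur together. All three steps start from a limit, so each gives a minimum and not an exact size, and the three sulfanyl compounds stay unranked among themselves: the limit of > 100000 nM in this assay, at which 3 of the 4 values shown sit.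

Compound 4 is the only sulfonyl compound shown, so it remains open whether a hexylsulfonyl or a (3-fluorobenzyl)sulfonyl group on the same carbon would keep, raise or lower the number, and where a propylsulfinyl group would fall. Also open, as far as these compounds go, is whether a readable number needs the sulfonyl itself or would also appear with another group at this place, such as an amine or a sulfonamide.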